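The source may hold more compounds than are shown below. What is called first, only, known or untested is meant among the compounds shown, and "the series" means these compounds.

Measured so far in a functional assay on a cell-free system (plasma) with sterol O-acyltransferase, Soat (Rattus norvegicus) as the target; a higher number here means that more compound is needed for the effect, a lower number that less compound is needed:

compound 1 `O=C(Nc1c(F)cc(F)cc1F)N(Cc1ccc(-c2cccs2)cc1)C1CCCCCC1`: > 1 mg/kg, a limit of the assay and not a number.
compound 2 `Cc1cc(C)c(NC(=O)N(Cc2ccc(-c3cccs3)cc2)C2CCCCCC2)c(C)c1`: 0.28 mg/kg.
compound 3 `O=C(Nc1c(F)cc(F)cc1F)N(Cc1ccc(-c2ccccn2)cc1)C1CCCCCC1`: > 1 mg/kg, again a limit, not a number.

Compound 2 thus stands alone with a real number in this assay; the other two sit at the limit of > 1 mg/kg in this assay, at which 2 of the 3 values shown sit, so no order among the three can be read beyond that. The step of an at least 3.5-fold lower number from compound 1 to compound 2 (0.55 log units; beyond the scatter) shows that swapping the ring on the urea nitrogen moves the number into the measurable range. The step that the two limits leave unreadable from compound 1 to compound 3, in contrast, says nothing usable, since both ends are limits.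

Compound 4 `Cc1cc(C)c(NC(=O)N(Cc2ccc(-n3cccn3)cc2)C2CCCCCC2)c(C)c1` is the not yet measured partner of compound 2, with the change (1H-pyrazol-1-yl in place of thiophen-2-yl on an aromatic carbon). Among the measured compounds shown here, the only measured step touching that same position, the exchange of the thiophene ring in compound 1 for a pyridine ring in compound 3, is unreadable, so the data give no guide to the size or direction of this step. A small change is expected, somewhat toward a higher number, with the estimate for compound 4 at 0.5 mg/kg, between 0.15 mg/kg and 2 mg/kg. The expected step is a 1.8-fold higher number from compound 2 to compound 4 (0.25 log units; within the scatter).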

Compound 4, dose for half-maximal effect: > 1 mg/kg
Compound 4 ended at the assay's limit (the forecaster's own chance of this, stated with the estimate: 25%); middle value at least 2.0-fold (0.30 log units) away from the limit.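

In this assay, among the compounds shown here, replacing thiophen-2-yl with 1H-pyrazol-1-yl gives an at least 3.5-fold higher number from compound 2 to compound 4 (0.55 log units; beyond the scatter), the first readable step at this place on the aromatic ring, since the earlier exchange of thiophen-2-yl for pyridin-2-yl had a limit at both ends and cannot be read. It shows that the place is sensitive to the choice of ring even when the size stays the same: both groups are five-membered aromatic rings with 5 heavy atoms, and they differ in having sulfur as 1 hetero atom or nitrogen as 2 hetero atoms. Compound 2 remains the only compound here with a real number, and the other compounds all share one limit: the limit of > 1 mg/kg in this assay, at which 3 of the 4 values shown sit.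

Going by these compounds, how far compound 4 lies past that limit remains open, and so does whether the sulfur atom itself matters or the thiophen-2-yl ring as a whole. Also open, on these data alone, is how the core of compound 2 would respond to other groups at this place, such as pyridin-2-yl, thiophen-3-yl, a plain phenyl ring, an amine or a carboxylic acid.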